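A Ring Swap at the Ring Nitrogen of a Pyrazoline Core

The source may hold more compounds than are shown below. What is called first, only, known or untested is meant among the compounds shown, and "the series" means these compounds.

Measured so far:
Compound 1, `Cc1ccc(C2=NN(C3=NC(c4ccccc4)CS3)C(c3ccc4ccccc4c3)C2)cc1`: 2460 nM
Compound 2, `O=C1CSC(N2N=C(c3ccc(Cl)cc3)CC2c2ccc3ccccc3c2)=N1`: 6320 nM

Both compounds were tested in a functional assay on HeLa cells (Homo sapiens) for inhibition, read by CCK-8 assay, with a stated time of 48 h; a higher number here means a weaker inhibitor, a lower number a stronger inhibitor. Compound 2 gives 6320 nM, the highest of the two numbers, and the nearest to it is compound 1, whose number is lower by a margin beyond the scatter. Compound 3, `Clc1ccc(C2=NN(C3=NC(c4ccccc4)CS3)C(c3ccc4ccccc4c3)C2)cc1`, has not been measured. It differs from compound 2 in one place: a group of 11 heavy atoms (9 carbon, 1 nitrogen, 1 sulfur; one five-membered non-aromatic ring with 2 hetero atoms, one six-membered aromatic ring of carbon only) in place of a group of 6 heavy atoms (3 carbon, 1 nitrogen, 1 oxygen, 1 sulfur; one five-membered non-aromatic ring with 2 hetero atoms), on an amine nitrogen in a ring. Compound 1 already carries the same entering group on the amine nitrogen in a ring of its core and differs from compound 3 only elsewhere, in the group on the ring atom two ring bonds away. Within the data shown here, with no measured step of this kind available, the expectation leans on compound 1, whose value of 2460 nM suggests that this group goes with a lower number than the group that leaves. Compound 3 is therefore expected at 2800 nM, with a range from 1200 nM to 6500 nM. The estimated step of a 2.3-fold lower number from compound 2 to compound 3 (0.35 log units; beyond the scatter) is a modest lowering, near the edge of the scatter.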

Compound 3, half-maximal inhibitory concentration: 7560 nM
Compound 3: the middle estimate sits 2.7-fold (0.43 log units) below what was measured, and the stated range ends below it.
By their numbers in this assay, from the lowest: compound 1; then compounds 2 and 3 (each within the scatter of the next).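

In this assay, the exchange on the amine nitrogen in a ring gives a 1.2-fold higher number from compound 2 to compound 3 (0.08 log units; within the scatter) with the 4-chlorophenyl group held fixed, so the two groups at this position, one of them much larger and carrying an added six-membered aromatic ring, cannot be told apart here. With the larger group held in place on that nitrogen, chloro in place of methyl on an aromatic carbon gives a 3.1-fold higher number from compound 1 to compound 3 (0.49 log units; beyond the scatter) as a modest step, so of the two single changes available, only this one lies beyond the scatter. Nothing measured here explains either step.

The compounds shown leave open whether the two groups on the ring nitrogen would still match with methyl in place of chloro on the aromatic ring, a comparison that would need the methyl partner of compound 2. They also leave open how the shared core would respond to a quite different group on that nitrogen, such as an open chain ending in an amine or a ring bearing a carboxylic acid.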